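Sulfonyl Aryl Swap and an Expected Antiproliferative Shift

The compounds below may be only part of what the source reports. "The series", "measured", "known", "first", "only" and "open" are said of these compounds alone.

Three compounds have been measured in a functional assay on SMMC-7721 cells (Homo sapiens) for antiproliferative activity, read by MTT assay, with a stated time of 72 h; a higher number here means a weaker inhibitor, a lower number a stronger inhibitor:

compound 1, `CN(c1ccc2[nH]c(-c3n[nH]c4ccccc34)cc2n1)S(=O)(=O)c1ccc(Br)cc1`: 11500 nM
compound 2, `COc1ccc(S(=O)(=O)N(C)c2ccc3[nH]c(-c4n[nH]c5ccccc45)cc3n2)cc1OC`: 26600 nM
compound 3, `COc1ccc(OC)c(S(=O)(=O)N(C)c2ccc3[nH]c(-c4n[nH]c5ccccc45)cc3n2)c1`: 4280 nM

Compound 3 carries the lowest number of the three. Its lead over compound 1 is a 2.7-fold lower number from compound 1 to compound 3 (0.43 log units; beyond the scatter), and over compound 2 it is a 6.2-fold lower number from compound 2 to compound 3 (0.79 log units; beyond the scatter); both gaps lie beyond the scatter. Between the other two, a 2.3-fold higher number from compound 1 to compound 2 (0.36 log units; beyond the scatter).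

Compound 4, `CN(c1ccc2[nH]c(-c3n[nH]c4ccccc34)cc2n1)S(=O)(=O)c1ccc(OC(F)(F)F)cc1`, differs from compound 3 in one place: 4-(trifluoromethoxy)phenyl in place of 2,5-dimethoxyphenyl on a sulfonyl sulfur. Among the compounds with values here, no measured step makes exactly this exchange. Within the data shown here, what bears on it is that compound 3 is the only member with a 2,5-dimethoxyphenyl group, and moving away from that group towards a ring substituted in a single position, as in compound 1, went with the change a 2.7-fold lower number from compound 1 to compound 3 (0.43 log units; beyond the scatter) read in reverse. Compound 1, whose ring is also substituted in one position, gives 11500 nM. A modest rise in number, roughly back to the level of compound 1, is therefore the likeliest outcome, though the new group has not been tested anywhere in this set.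

Compound 4 is expected to give 12000 nM, within a range of 4000 nM to 36000 nM, which corresponds to an estimated step of a 2.8-fold higher number from compound 3 to compound 4 (0.45 log units; beyond the scatter).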

Compound 4, half-maximal inhibitory concentration: 7160 nM
Compound 4: the middle estimate sits 1.7-fold (0.22 log units) above what was measured; low and high end bracket the measured number.
By their numbers in this assay, from the lowest: compounds 3, 4 and 1 (each within the scatter of the next, the first and the last beyond it); then compound 2.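

In this assay the 4-(trifluoromethoxy)phenyl group on the sulfonyl sulfur gives a 1.7-fold higher number from compound 3 to compound 4 (0.22 log units; within the scatter) when it replaces 2,5-dimethoxyphenyl and a 1.6-fold lower number from compound 1 to compound 4 (0.21 log units; within the scatter) when trifluoromethoxy replaces bromo on an aromatic carbon, so compound 4 cannot be told apart from either neighbour. Compounds 1 and 3 do lie beyond the scatter of each other, which means that the earlier picture of a clear gap between a ring substituted in one place and the 2,5-dimethoxyphenyl ring now has a member sitting within reach of both, and a single substituent does not by itself cost activity at this position. The one clear separation for the new group is a 3.7-fold lower number from compound 2 to compound 4 (0.57 log units; beyond the scatter), which leaves the 3,4-dimethoxyphenyl compound 2 alone at the weak end of the set, though nothing available here explains any of these steps.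

Going by these compounds, whether a phenyl ring bearing an amine or a carboxylic acid would stay at this level remains open, as does the outcome of a plain alkyl chain on the sulfonyl sulfur in place of the aromatic ring. The compounds shown also all keep the same core and the same methyl group on the sulfonamide nitrogen, so what a change at either of those places would do stays unknown.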